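From hydroxy-methoxyphenyl to aminophenyl on a shared core

This account rests on a few compounds, and the source may have more. Where it says the series, first, only, none or still open, it means among the compounds named here.

Compound 2 `COc1ccc(-c2ccc3ncn(-c4cc(OC)c(OC)c(OC)c4)c3c2)cc1O` gives 44 nM in a functional assay on SGC-7901 cells (Homo sapiens) for antiproliferative activity, read by MTT assay, with a stated time of 72 h (a lower number here means a stronger inhibitor, a higher number a weaker inhibitor), and holds the only number shown there. In this assay compound 1 `COc1cc(-n2cnc3ccc(-c4ccccc4Cl)cc32)cc(OC)c1OC` gives > 10000 nM, which is a limit of the assay (the limit of > 10000 nM in this assay, at which 1 of the 2 values shown sits). The step of an at least 220-fold lower number from compound 1 to compound 2 (2.35 log units; beyond the scatter) shows how strongly the aryl group on the shared core sets the read-out. Compound 3 `COc1cc(-n2cnc3ccc(-c4cccc(N)c4)cc32)cc(OC)c1OC` carries 3-aminophenyl in place of 3-hydroxy-4-methoxyphenyl on an aromatic carbon. Going by the values given here, only that one measured step bears on this change, and it was large. Compound 3 is therefore expected to be a weaker inhibitor, estimated at 500 nM (range 100 nM to 3000 nM), a step of an 11-fold higher number from compound 2 to compound 3 (1.06 log units; beyond the scatter).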

Compound 3, half-maximal inhibitory concentration: 21 nM
Compound 3: middle estimate off by 24-fold (1.38 log units), on the high side; the measured number lies below the stated range.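

In this assay, the 3-hydroxy-4-methoxyphenyl group is not required at this aromatic carbon: 3-aminophenyl in its place gives a 2.1-fold lower number from compound 2 to compound 3 (0.32 log units; beyond the scatter), a modest step. The contrast with 2-chlorophenyl is far larger, at an at least 470-fold lower number from compound 1 to compound 3 (2.67 log units; beyond the scatter), so a second substituted phenyl group now stands well clear of compound 1. That step rests on a limit for compound 1, not on a number: the limit of > 10000 nM in this assay, at which 1 of the 3 values shown sits.

Going by these compounds, it remains open how far this level of activity depends on the amine itself. A methylamino group, an amide or a carboxylic acid in its place could read quite differently.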